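A few compounds are considered here, and "the series" means these few. Any claim that something is new, unique, unknown or untested is made for them only; others in the source may bear on it.

For the measured compounds named here, compound 1 `COc1ncnc2c1c(-c1cccs1)cn2[C@@H]1O[C@H](CO)[C@@H](O)[C@H]1O` is the only compound with a numerical result so far: in a functional assay on HCT-116 cells (Homo sapiens), read by MTT assay, with a stated time of 72 h (on this read-out higher numbers stand for weaker inhibition and lower numbers for stronger inhibition), compound 1 gives 440 nM. Going by the values given here, compound 2 `COc1nc(N)nc2c1c(-c1cccs1)cn2[C@@H]1O[C@H](CO)[C@@H](O)[C@H]1O` is the only other compound tested. In this assay compound 2 gives > 20000 nM, which is a limit of the assay rather than a number. Among the compounds with values here, the single measured step is an at least 45-fold higher number from compound 1 to compound 2 (1.65 log units; beyond the scatter), and its size is only a lower bound because compound 2 sits at the limit of > 20000 nM in this assay, at which 1 of the 2 values shown sits. Compound 3 `CNc1ncnc2c1c(-c1cccs1)cn2[C@@H]1O[C@H](CO)[C@@H](O)[C@H]1O` has not yet been tested; it differs from compound 1 by methylamino in place of methoxy on an aromatic carbon. Within the data shown here, the measured step concerns an added amino group at a different carbon of the shared core, so no measured step bears directly on this change. Without a directly comparable step, only a modest step in this assay is expected, in no clear direction. The estimate for compound 3 in this assay is 300 nM, between 60 nM and 2000 nM, which corresponds to an expected 1.5-fold lower number from compound 1 to compound 3 (0.17 log units; within the scatter).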

Compound 3, half-maximal inhibitory concentration: > 20000 nM
Compound 3 was reported as a limit; the forecaster's own chance of this, stated with the estimate: 10%; at least 66-fold (1.82 log units) between middle value and limit.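

This is the first change shown at the carbon that carries the methoxy group, and it matters greatly there. In this assay, replacing methoxy with methylamino gives an at least 45-fold higher number from compound 1 to compound 3 (1.65 log units; beyond the scatter), even though both groups have the same number of heavy atoms and neither carries a net charge. The result for compound 3 is a limit of the assay and not a number, so the true size of the step stays unknown: the limit of > 20000 nM in this assay, at which 2 of the 3 values shown sit.

The compounds shown leave open whether the loss follows from the hydrogen-bond donor that enters with methylamino or from the exchange of oxygen for nitrogen, a question that dimethylamino at this carbon could help to separate. As far as these compounds go, it also remains open how an ethoxy group or a chlorine atom would fare at this carbon.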